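A Substituted Benzoyl on a Weakly Active Series

The source may hold more compounds than are shown below. What is called first, only, known or untested is meant among the compounds shown, and "the series" means these compounds.

In a functional assay on HT-29 cells (Homo sapiens) for inhibition, read by MTT assay, with a stated time of 48 h (a higher number here means a weaker inhibitor, a lower number a stronger inhibitor), compound 1 `COc1cc(-c2nnc(SCc3ccccc3)n2-c2ccc(N(C)C)cc2)cc(OC)c1OC` reaches only a limit, > 60000 nM. Compound 2 `COc1cc(-c2nnc(SCc3ccc(F)cc3)n2-c2ccc(N(C)C)cc2)cc(OC)c1OC` gives 44300 nM, and compound 3 `COc1cc(-c2nnc(SCC(=O)c3ccccc3)n2-c2ccc(N(C)C)cc2)cc(OC)c1OC` gives 45200 nM. These two numbers are separated by a 1.0-fold higher number from compound 2 to compound 3 (0.01 log units; within the scatter), so compound 3 stands level with compound 2.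

Compound 4 `COc1ccc(C(=O)CSc2nnc(-c3cc(OC)c(OC)c(OC)c3)n2-c2ccc(N(C)C)cc2)cc1O` carries 3-hydroxy-4-methoxyphenyl in place of phenyl on a carbonyl carbon. Going by the values given here, no measured step tests a change at this place. The closest guides are an at least 1.3-fold lower number from compound 1 to compound 3 (0.12 log units; that floor lies within the scatter), with benzoyl in place of phenyl, and an at least 1.3-fold lower number from compound 1 to compound 2 (0.13 log units; that floor lies within the scatter), with fluoro in place of hydrogen on an aromatic carbon. Both are floors, so they show only a small shift toward lower numbers and leave its true size open. The enlarged group in compound 4 is a bigger change than either, so a modest move in the same direction is expected. The expected step is a 2.3-fold lower number from compound 3 to compound 4 (0.35 log units; beyond the scatter). Compound 4 is estimated at 20000 nM, with an expected range of 4000 nM to 60000 nM.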

Compound 4, half-maximal inhibitory concentration: > 60000 nM
Compound 4: no number, only a limit; the forecaster's own chance of this, stated with the estimate: 20%; middle value at least 3.0-fold (0.47 log units) from the limit.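

This is the only change shown on the carbonyl carbon, and 3-hydroxy-4-methoxyphenyl in place of phenyl brings no fall in the number: the result is an at least 1.3-fold higher number from compound 3 to compound 4 (0.12 log units; that floor lies within the scatter). On these data alone, with (3-hydroxy-4-methoxyphenyl)carbonyl in place of 4-fluorophenyl on the saturated chain carbon bound to a sulfur, the result is an at least 1.3-fold higher number from compound 2 to compound 4 (0.13 log units; that floor lies within the scatter), and as both floors lie within the scatter, the true size of either step stays open. Compound 4 gives only a limit in this assay, and the step linking it to compound 1 cannot be read, the two limits leaving it open: the limit of > 60000 nM in this assay, at which 2 of the 4 values shown sit.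

The compounds shown leave open whether the hydroxy or the methoxy group alone would give the same reading on that phenyl. They also leave open how an amine or a carboxylic acid in that place would read.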